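The source may report more compounds than this note shows. Statements on the series, on what has been measured and on what is new or still open speak of the compounds shown alone.

In a functional assay on THP-1 cells (Homo sapiens) for antiproliferative activity, read by luminescence, with a stated time of 72 h (a higher number here means a weaker inhibitor, a lower number a stronger inhibitor), compound 2 (`COc1cc(O)c(C(=O)OCC(C)c2ccccc2)c(/C=C/CN2C(=O)C=CC2=O)c1`) reads > 10000 nM, which is a limit of the assay and not a number. Compound 3 (`COc1cc(O)c(C(=O)OCC2CCCCC2)c(/C=C/CN2C(=O)C=CC2=O)c1`) differs from it in one place, cyclohexyl in place of 1-phenylethyl on a saturated chain carbon bound to an oxygen next to a carbonyl group. Compound 1 (`C=CS(=O)(=O)NC/C=C/c1cc(OC)cc(O)c1C(=O)OCC1CCCCC1`), which carries the same cyclohexylmethoxy group on a different side chain, gives 7880 nM in this assay. On that value, the expected change is a small gain in strength, an at least 1.6-fold lower number from compound 2 to compound 3 (0.22 log units; that floor lies within the scatter). Compound 3 is estimated at 6000 nM, with an expected range of 1500 nM to 10000 nM.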

Compound 3, half-maximal inhibitory concentration: 7710 nM
For compound 3 the middle estimate is 1.3-fold (0.11 log units) below the measured one; low and high end bracket the measured number.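

In this assay compound 2 holds only a limit of the assay and not a number: the limit of > 10000 nM in this assay, at which 1 of the 3 values shown sits.

Cyclohexyl in place of 1-phenylethyl can thus be read only as a floor, an at least 1.2-fold lower number from compound 2 to compound 3 (0.11 log units; that floor lies within the scatter), so its true size stays unknown. With the cyclohexylmethoxy group shared, the two side chains stay within the scatter, a 1.0-fold lower number from compound 1 to compound 3 (0.01 log units; within the scatter).

The compounds shown leave open how far the true value of compound 2 lies beyond its limit. They also leave open how an ethyl group, or a cyclohexyl ring carrying an amine, would read at this place.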